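Fluoro to acetamido: expected cytotoxicity of compound 3

The source may hold more compounds than are shown below. What is called first, only, known or untested is meant among the compounds shown, and "the series" means these compounds.

In an ADME assay on L02 cells (Homo sapiens) for cytotoxicity, read by MTT assay, with a stated time of 24 h (on this read-out higher numbers stand for weaker inhibition and lower numbers for stronger inhibition), compound 1 (`COc1cc(/C=C2\CN(S(=O)(=O)c3ccc(F)cc3)C/C(=C\c3cc(OC)cc(OC)c3)C2=O)cc(OC)c1`) gives 19800 nM and compound 2 (`COc1cc(/C=C2\CN(S(=O)(=O)c3ccc(F)cc3)C/C(=C\c3ccccc3F)C2=O)cc(OC)c1`) gives 18500 nM and so stands within the scatter of compound 1. Compound 3 (`COc1cc(/C=C2\CN(S(=O)(=O)c3ccc(NC(C)=O)cc3)C/C(=C\c3ccccc3F)C2=O)cc(OC)c1`) follows from compound 2 by one change (acetamido in place of fluoro on an aromatic carbon), 4-fluorophenyl to 4-acetamidophenyl. Among the measured compounds shown here, the only measured step (a 1.1-fold lower number from compound 1 to compound 2 (0.03 log units; within the scatter)) lies within the scatter and sits elsewhere in the molecule, so it gives no direct guide here. For the measured compounds named here, no measured step covers this place, so no direction is expected, and the expected step (a 1.0-fold higher number from compound 2 to compound 3 (0.01 log units; within the scatter)) stays within the scatter. The estimate for compound 3 is 19000 nM with an expected range from 8000 nM to 45000 nM around it.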

Compound 3, half-maximal inhibitory concentration: 15400 nM
Beside the measured number, compound 3's estimate is 1.2-fold (0.09 log units) above it; the range from low to high includes it.
By their numbers in this assay, from the lowest: compounds 3, 2 and 1 (each within the scatter of the next).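

In this assay, the change from 4-fluorophenyl to 4-acetamidophenyl gives the first step measured at this place, a 1.2-fold lower number from compound 2 to compound 3 (0.08 log units; within the scatter), so it stays within the scatter. Fluoro, with 1 heavy atom, thus gives way to acetamido, with 4 heavy atoms, a hydrogen-bond donor and a hydrogen-bond acceptor, with no step beyond the scatter on this read-out. No evidence on the reason for this result is available here.

Going by these compounds, whether an amine, a carboxylic acid or a longer chain at this place would give a step beyond the scatter remains open. Also open, on these data alone, is whether the same change gives a similar step on the core of compound 1.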